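Replacing the acid on the benzyl group of an FXR agonist

This account rests on a few compounds, and the source may have more. Where it says the series, first, only, none or still open, it means among the compounds named here.

Two compounds from a series built on a shared core have been measured in an assay on isolated protein for agonist activity at Bile acid receptor (Homo sapiens), read by FRET; on this read-out lower numbers stand for an effect already at smaller amounts and higher numbers for an effect only at larger amounts of compound. Compound 1 `CC(C)c1onc(-c2c(Cl)cccc2Cl)c1COc1ccc(NC(=O)c2ccc(C(=O)O)cc2)c(C(F)(F)F)n1` gives 452 nM. Compound 2 `CC(C)c1onc(-c2c(Cl)cccc2Cl)c1COc1ccc(N(C)Cc2cccc(C(=O)O)c2)c(C(F)(F)F)n1` gives 12 nM, the lowest of the two numbers, with compound 1 the nearer and only neighbour; the change a 38-fold lower number from compound 1 to compound 2 (1.58 log units; beyond the scatter) is large and lies beyond the scatter. Compound 3 `CC(C)c1onc(-c2c(Cl)cccc2Cl)c1COc1ccc(N(C)Cc2ccc(OCCO)cc2)c(C(F)(F)F)n1` differs from compound 2 in one place: 4-(2-hydroxyethoxy)phenyl in place of 3-carboxyphenyl on a saturated chain carbon bound to a nitrogen on an aromatic ring. Going by the values given here, no measured step bears directly on this change; the step from compound 1 to compound 2 altered the linker and the position of the carboxylic acid together, but never removed the acid, so it is only a loose guide. Because both measured compounds carry a carboxylic acid and the lower number belongs to compound 2 with 12 nM, the estimate for compound 3 is a higher number, a 17-fold higher number from compound 2 to compound 3 (1.22 log units; beyond the scatter), at 200 nM with a range from 30 nM to 1500 nM.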

Compound 3, half-maximal effective concentration: 164 nM
Estimate against measurement, compound 3: 1.2-fold (0.09 log units) above; measured number inside the range.
By their numbers in this assay, from the lowest: compound 2; then compound 3; then compound 1.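

Going by these compounds alone, with the linker held constant, this is the first step in which the carboxylic acid leaves the benzyl position: in this assay, replacing 3-carboxyphenyl with 4-(2-hydroxyethoxy)phenyl gives a 14-fold higher number from compound 2 to compound 3 (1.14 log units; beyond the scatter) and marks a large change beyond the scatter. Compound 3 still gives a measurable number without a carboxylic acid, so an acid at this position is not a requirement for a read-out in this assay. No supporting data bear on why the number rises.

Within the data shown here, the single step changes both the group and its place on the ring, so the two contributions cannot be separated. On these data alone, it remains open how a 4-carboxyphenyl group, or a longer chain ending in an amine, would fare on the same linker.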